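Aryloxy naphthoquinones: thiophene to furan swap in cytotoxicity

A few compounds are considered here, and "the series" means these few. Any claim that something is new, unique, unknown or untested is made for them only; others in the source may bear on it.

Measured compounds:
compound 1 `O=C1C=CC(=O)c2c(Oc3ccco3)cccc21`: 13400 nM
compound 2 `O=C1C=CC(=O)c2c(Oc3cccs3)cccc21`: 6230 nM
compound 3 `O=C1C=C(Oc2cccs2)C(=O)c2ccccc21`: 41500 nM

Three compounds have been run in a functional assay on KB cells (Homo sapiens) for cytotoxicity; on this read-out higher numbers stand for weaker inhibition and lower numbers for stronger inhibition. Compound 2 gives 6230 nM, and compound 1 gives 13400 nM. The two differ by one change, (furan-2-yl in place of thiophen-2-yl on an oxygen on an aromatic ring), and the step is a 2.2-fold higher number from compound 2 to compound 1 (0.33 log units; beyond the scatter).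

Compound 3 gives 41500 nM, the highest number of the three, and its gaps to compound 1 and compound 2 both lie beyond the scatter. Compound 3 and compound 2 have the same atoms joined differently; the difference between the two cores is not broken down here.

Compound 4 `O=C1C=C(Oc2ccco2)C(=O)c2ccccc21` is not yet measured in this assay. It differs from compound 3 by furan-2-yl in place of thiophen-2-yl on an oxygen on an unsaturated carbon. This is the same kind of change as from compound 2 to compound 1, but not the same: there the place is on an oxygen on an aromatic ring whose other neighbours are aromatic carbon, here it is on an oxygen on an unsaturated carbon whose other neighbours are a double-bonded ring carbon. Going by the values given here, with only one prior instance, and that at a different place, the step is expected to be of similar size but is uncertain. In this assay, among the compounds with values here, the step from compound 3 to compound 4 is estimated at a 2.0-fold higher number from compound 3 to compound 4 (0.31 log units; beyond the scatter), because a 2.2-fold higher number from compound 2 to compound 1 (0.33 log units; beyond the scatter) is the only guide available. Compound 4 is accordingly estimated at 85000 nM, with a range from 35000 nM to 200000 nM.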

Compound 4, half-maximal inhibitory concentration: 53400 nM
For compound 4 the middle estimate is 1.6-fold (0.20 log units) above the measured one, within the range that was stated.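

In this assay, furan-2-yl in place of thiophen-2-yl on an oxygen on an unsaturated carbon gives a 1.3-fold higher number from compound 3 to compound 4 (0.11 log units; within the scatter), so on this core the swap cannot be told apart from the scatter of repeated measurements. Set beside the same swap on the core of compound 1, the result gives no sign that the two cores respond differently, and the change can be treated as carrying across them within the present resolution: the same change on two cores in this assay, a 2.2-fold higher number (0.33 log units; beyond the scatter) from compound 2 to compound 1 and a 1.3-fold higher number (0.11 log units; within the scatter) from compound 3 to compound 4, 1.7-fold (0.22 log units) apart, within the scatter of two such steps. This does not show that the step has a fixed size or direction, nor that the core governs it, since one step lies beyond the scatter and the other within it, and a single pair on each of two cores cannot separate a small shared step from two unrelated ones.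

The compounds shown carry only thiophen-2-yl and furan-2-yl on the oxygen, so it remains open how a phenyl ring or a longer chain such as butyl would read in this assay on either core. Also open, from the compounds shown here alone, is whether an amine in place of the linking oxygen would leave the number where it stands or move it well beyond the scatter.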